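Swapping 4-Aminophenyl for Thiophen-3-yl at the Carbonyl

A few compounds are considered here, and "the series" means these few. Any claim that something is new, unique, unknown or untested is made for them only; others in the source may bear on it.

Measured compounds:
compound 1 `COc1ccc(C(=O)/C=C/c2nc3ccccc3cc2-c2ccc(OC)cc2)cc1` gives 7540 nM
compound 2 `COc1ccc(-c2cc3ccccc3nc2/C=C/C(=O)c2ccc(OC)cc2OC)cc1` gives 3210 nM
compound 3 `COc1ccc(-c2cc3ccccc3nc2/C=C/C(=O)c2ccc(N)cc2)cc1` gives 7510 nM

In a functional assay on MDA-MB-231 cells (Homo sapiens) for antiproliferative activity, read by XTT assay, with a stated time of 72 h (a lower number here means a stronger inhibitor, a higher number a weaker inhibitor), compound 3 stands second highest of the three numbers. Its nearest neighbour is compound 1, reached by a 1.0-fold lower number from compound 1 to compound 3 (0.00 log units; within the scatter), a step within the scatter. Compound 2 is the furthest away, the gap being a 2.3-fold higher number from compound 2 to compound 3 (0.37 log units; beyond the scatter), a modest step beyond the scatter.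

Compound 4 `COc1ccc(-c2cc3ccccc3nc2/C=C/C(=O)c2ccsc2)cc1` differs from compound 3 in one place: thiophen-3-yl in place of 4-aminophenyl on a carbonyl carbon. Going by the values given here, two measured steps touch the same region. The step of a 1.0-fold lower number from compound 1 to compound 3 (0.00 log units; within the scatter) changed only a substituent on that aryl group and left the number where it was, while a 2.3-fold higher number from compound 2 to compound 3 (0.37 log units; beyond the scatter) replaced the whole aryl group and moved the number modestly. Changes at this position have therefore given at most a modest shift in this assay, in either direction, and nothing among the measured compounds tells which way a five-membered ring would go.

Compound 4 is accordingly expected to give about 7500 nM in this assay, within a range of 2800 nM to 20000 nM, meaning an expected step of a 1.0-fold lower number from compound 3 to compound 4 (0.00 log units; within the scatter) that is not beyond the scatter.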

Compound 4, half-maximal inhibitory concentration: 1060 nM
Beside the measured number, compound 4's estimate is 7.1-fold (0.85 log units) above it, and the stated range ends above it.
By their numbers in this assay, from the lowest: compound 4; then compound 2; then compounds 3 and 1 (each within the scatter of the next).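

In this assay, going by these compounds alone, the group on the carbonyl carbon proves able to move the number further than the earlier compounds showed, with thiophen-3-yl giving a 7.1-fold lower number from compound 3 to compound 4 (0.85 log units; beyond the scatter) and likewise a 7.1-fold lower number from compound 1 to compound 4 (0.85 log units; beyond the scatter). The five-membered ring also improves on the 2,4-dimethoxyphenyl group, the best of the six-membered aryl groups shown, with a 3.0-fold lower number from compound 2 to compound 4 (0.48 log units; beyond the scatter), so compound 4 has the lowest number of the four, beyond the scatter from each of the others. No evidence is available on why the number falls with this change.

The compounds shown leave open whether the gain belongs to the sulfur-containing ring or to the five-membered ring as such, a question that thiophen-2-yl, furan-3-yl and plain phenyl on the same carbonyl carbon would address. They also leave open whether a methyl or chloro group on the thiophen-3-yl ring would lower the number further.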